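Lengthening the Chain of Compound 3

The source may report more compounds than this note shows. Statements on the series, on what has been measured and on what is new or still open speak of the compounds shown alone.

In a functional assay on HCT-116 cells (Homo sapiens) for inhibition, read by MTT assay, with a stated time of 72 h (on this read-out lower numbers stand for stronger inhibition and higher numbers for weaker inhibition), compound 3 (`Nc1nc2cc(-c3nn(CCC(=O)NO)c4ncnc(N)c34)ccc2o1`) shows > 100000 nM and this is a limit, not a number. Among the compounds with values here, compound 2 (`Nc1ncnc2c1c(-c1cnc3[nH]ccc3c1)nn2CC(=O)NO`) also sits at a limit, with > 150000 nM as its only reading. Compound 1 (`CNC(=O)CCCCCCCn1nc(-c2cnc3[nH]ccc3c2)c2c(N)ncnc21`) gives a true number of 6760 nM with its 6-(methylcarbamoyl)hexyl chain. Compound 4 (`Nc1nc2cc(-c3nn(CCCCCCC(=O)NO)c4ncnc(N)c34)ccc2o1`) is unmeasured and has 4-(hydroxycarbamoyl)butyl in place of hydroxycarbamoyl on a saturated chain carbon (4-(hydroxycarbamoyl)butyl in place of hydroxycarbamoyl on a saturated chain carbon, two bonds along the chain from an aromatic nitrogen). Within the data shown here, the one measured step that bears on this (an at least 22-fold higher number from compound 1 to compound 2 (1.34 log units; beyond the scatter)) was large and shortened the chain, so it runs the opposite way. Lengthening is therefore expected to bring a large step towards lower numbers (an at least 66-fold lower number from compound 3 to compound 4 (1.82 log units; beyond the scatter)). In this assay compound 4 is expected at 1500 nM (range 150 nM to 15000 nM).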

Compound 4, half-maximal inhibitory concentration: 5390 nM
For compound 4 the middle estimate is 3.6-fold (0.56 log units) below the measured one, within the range that was stated.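

In this assay, lengthening the chain gives an at least 18-fold lower number from compound 3 to compound 4 (1.26 log units; beyond the scatter), so with the hydroxycarbamoyl end kept, chain length alone matters at this position. The earlier step changed the chain and its end group together, whereas here only the length changes. The true size of the step stays unknown because compound 3 gives a limit, not a number: the limit of > 100000 nM in this assay, at which 1 of the 4 values shown sits.

From the compounds shown here alone, whether a chain of intermediate length or a still longer chain would give lower numbers remains open. So does the effect of a carboxylic acid replacing the hydroxycarbamoyl end on the same long chain.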